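This account rests on a few compounds, and the source may have more. Where it says the series, first, only, none or still open, it means among the compounds named here.

Compound 2 `CC1CC/C(=N\Nc2ccccc2Cl)c2ncc(C(=O)O)c(=O)n21` and compound 1 `CC1CC/C(=N\Nc2ccccc2)c2ncc(C(N)=O)c(=O)n21` share one core and differ in the aryl group and the acid or amide side chain. In a functional assay on the whole organism for inhibition, with Rattus norvegicus as the target (on this read-out higher numbers stand for an effect only at larger amounts of compound and lower numbers for an effect already at smaller amounts), compound 2 gives > 1000 umol/kg, which is a limit of the assay and not a number. In this assay compound 1 gives > 1000 umol/kg, likewise only a limit. What is known so far is the limit of > 1000 umol/kg in this assay, at which 2 of the 2 values shown sit. Compound 3 `CC1CC/C(=N\Nc2ccc(I)cc2)c2ncc(C(=O)O)c(=O)n21` differs from compound 2 by 4-iodophenyl in place of 2-chlorophenyl on an amine nitrogen. For the measured compounds named here, no measured step exists to size this change; a step from compound 2 to compound 3 of a number no higher from compound 2 to compound 3 (the limit leaves the size open) is expected, none beyond the scatter. Compound 3 is expected near 1000 umol/kg, between 300 umol/kg and 3000 umol/kg, most likely reported again as a limit.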

Compound 3, dose for 50% inhibition: > 1000 umol/kg
Compound 3: no number, only a limit; the forecaster's own chance of this, stated with the estimate: 75%; the middle value sits exactly at the limit.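

For the compounds shown here, no step from compound 2 to compound 3 can be read in this assay, as both values are limits and not numbers: the limit of > 1000 umol/kg in this assay, at which 3 of the 3 values shown sit. Still open, going by these compounds, is whether any aryl group or side chain on the shared core gives a measured dose rather than a limit.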